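A branched chain on the oxygen of compound 3

The source may report more compounds than this note shows. Statements on the series, on what has been measured and on what is new or still open speak of the compounds shown alone.

Of the compounds shown here, three sharing one core have been tested in an assay on liver for inhibition of sterol O-acyltransferase 1 (Rattus norvegicus), using microsomes; on this read-out higher numbers stand for weaker inhibition and lower numbers for stronger inhibition. Compound 1 `CCCCCCNS(=O)(=O)NC(=O)Nc1c(C(C)C)cccc1C(C)C` gives 8100 nM. Compound 2 `CC(C)CN(CC(C)C)S(=O)(=O)NC(=O)Nc1c(C(C)C)cccc1C(C)C` gives 420 nM, and compound 3 `CCCCCCOS(=O)(=O)NC(=O)Nc1c(C(C)C)cccc1C(C)C` gives 27000 nM. Compound 3 therefore shows the highest number of the three: the step of a 3.3-fold higher number from compound 1 to compound 3 (0.52 log units; beyond the scatter) is modest, while the step of a 64-fold higher number from compound 2 to compound 3 (1.81 log units; beyond the scatter) is large, and the step of a 19-fold lower number from compound 1 to compound 2 (1.29 log units; beyond the scatter) sets compound 2 apart as the strongest inhibitor in this set.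

Compound 4 `CCCCCCC(C)OS(=O)(=O)NC(=O)Nc1c(C(C)C)cccc1C(C)C` keeps the core and the oxygen link of compound 3 and changes only the chain on that oxygen: 1-methylheptyl in place of hexyl on an oxygen. Within the data shown here, none of the measured steps alters a chain in this way; the steps seen so far swap the whole group that sits on the sulfonyl sulfur. The nearest hint is the large step of a 19-fold lower number from compound 1 to compound 2 (1.29 log units; beyond the scatter), in which a branched group went with a much lower number, but that change sits on a nitrogen rather than on an oxygen, so it bears only loosely on compound 4. A modest step downward is expected in this assay, with wide uncertainty. For compound 4 the estimate is 10000 nM, between 3000 nM and 40000 nM, meaning an expected step of a 2.7-fold lower number from compound 3 to compound 4 (0.43 log units; beyond the scatter).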

Compound 4, half-maximal inhibitory concentration: 35000 nM
For compound 4 the middle estimate is 3.5-fold (0.54 log units) below the measured one; the measured number falls inside the stated range.
By their numbers in this assay, from the lowest: compound 2; then compound 1; then compounds 3 and 4 (each within the scatter of the next).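

In this assay, putting 1-methylheptyl in place of hexyl on an oxygen whose other neighbour is the sulfonyl sulfur gives a 1.3-fold higher number from compound 3 to compound 4 (0.11 log units; within the scatter), so this read-out does not separate the two chains, although one has 8 heavy atoms and the other 6. The oxygen-linked compound 4 also stays apart from both nitrogen-linked compounds: a 4.3-fold higher number from compound 1 to compound 4 (0.64 log units; beyond the scatter) is a modest step and an 83-fold higher number from compound 2 to compound 4 (1.92 log units; beyond the scatter) is a large one, so a branched chain on this oxygen does not give a number close to that of compound 2, whose branched chains sit on a nitrogen. No measurement is available that could explain why the change of chain on this oxygen leaves the number within the scatter.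

Only two chains on this oxygen are shown, so it remains open whether a shorter chain such as butyl, or a benzyl group, would shift the number. Going by these compounds, it also remains open whether an isobutyl chain on this oxygen, the kind of chain found in the diisobutylamino group of compound 2, would give a much lower number.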